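The source may hold more compounds than are shown below. What is called first, only, known or untested is meant among the compounds shown, and "the series" means these compounds.

Of the compounds shown here, three of one shared core have been measured so far. Compound 1 `C=CCn1c(=O)/c(=C\c2cccc(F)c2)[nH]c(=O)/c1=C\c1ccccc1OC` gives 19700 nM in a functional assay on A549 cells (Homo sapiens) for cytotoxicity, read by CCK-8 assay, with a stated time of 72 h; on this read-out higher numbers stand for weaker inhibition and lower numbers for stronger inhibition; compound 2 `C=CCn1c(=O)/c(=C\c2cccc(Br)c2)[nH]c(=O)/c1=C\c1ccccc1OC` gives 5400 nM; compound 3 `C=CCn1c(=O)/c(=C\c2ccccc2OC)[nH]c(=O)/c1=C\c1ccccc1OC` gives 22400 nM. Compound 2 therefore has the lowest number of the three, and its lead over each of the other two lies beyond the scatter.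

Compound 4 `C=CCn1c(=O)/c(=C\c2cccc(Br)c2)[nH]c(=O)/c1=C\c1cccc(Br)c1` is not yet measured. It differs from compound 2 in one place: 3-bromophenyl in place of 2-methoxyphenyl on a double-bonded chain carbon bound to an aromatic carbon.

Among the compounds with values here, two measured steps bear on this change. Exchanging a 3-bromophenyl for a 2-methoxyphenyl on the double-bonded chain carbon gave a 4.1-fold higher number from compound 2 to compound 3 (0.62 log units; beyond the scatter), so the reverse exchange, now on the other side of the core, may be expected to pull the number down by a similar amount. Putting bromo in place of fluoro gave a 3.6-fold lower number from compound 1 to compound 2 (0.56 log units; beyond the scatter), again pointing toward a lower number with a bromo-bearing ring. The expected step is therefore a 2.3-fold lower number from compound 2 to compound 4 (0.35 log units; beyond the scatter), a modest lowering, although the two sides of the core need not behave alike. Compound 4 is estimated at 2400 nM, within a range from 1000 nM to 6000 nM.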

Compound 4, half-maximal inhibitory concentration: "not active" (no number reported)
The entry for compound 4 holds no number; no gap can be computed for the estimate.
By their numbers in this assay, from the lowest: compound 2; then compounds 1 and 3 (each within the scatter of the next).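

In this assay, within the data shown here, compound 4 is reported as "not active" with no number, so no step from compound 2 to compound 4 can be read. As far as these compounds go, how far compound 4 lies from compound 2 stays open. No measurement shown explains this result.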